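Chromene benzophenone amides: bromoacetamide to methylaminoacetamide

This account rests on a few compounds, and the source may have more. Where it says the series, first, only, none or still open, it means among the compounds named here.

Measured compounds:
compound 1 `COc1ccc(C(=O)c2ccc(OC)c3c2C=CC(C)(C)O3)c(NC(=O)CBr)c1`: 2460 nM
compound 2 `CNCC(=O)Nc1cc(OC)ccc1C(=O)c1ccc(OC)c2c1OC(C)(C)C=C2`: 620 nM

In a functional assay on A549 cells (Homo sapiens) for antiproliferative activity, read by MTT assay, with a stated time of 48 h (a higher number here means a weaker inhibitor, a lower number a stronger inhibitor), compound 1 gives 2460 nM, the higher of the two numbers; compound 2 gives 620 nM, a lower number beyond the scatter. Compound 3 `CNCC(=O)Nc1cc(OC)ccc1C(=O)c1ccc(OC)c2c1C=CC(C)(C)O2` keeps the core of compound 1 and differs from it by methylamino in place of bromo on a saturated chain carbon bound to a carbonyl carbon. For the measured compounds named here, no measured pair shows this change on this core. Compound 2 carries the same side chain as compound 3 and its value stands well below compound 1. The step from compound 1 to compound 3 is therefore expected to be a moderate gain, a 3.1-fold lower number from compound 1 to compound 3 (0.49 log units; beyond the scatter). Compound 3 is estimated at 800 nM, within 300 nM to 2500 nM.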

Compound 3, half-maximal inhibitory concentration: 1370 nM
Estimate against measurement, compound 3: 1.7-fold (0.23 log units) below, and the stated range covers the measured number.
By their numbers in this assay, from the lowest: compound 2; then compounds 3 and 1 (each within the scatter of the next).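

For the compounds shown here, this is the first reading of this change on the core of compound 1. In this assay, methylamino in place of bromo on a saturated chain carbon bound to a carbonyl carbon gives a 1.8-fold lower number from compound 1 to compound 3 (0.25 log units; within the scatter), so at this position the exchange does not separate the two compounds. Nothing available bears on a cause for this result.

Open, on these data alone, is whether a dimethylamino group, a piperazine or a longer chain at this position would give a step beyond the scatter on this core. Also open, as far as these compounds go, is how bromo and methylamino compare on the core of compound 2.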